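The source may report more compounds than this note shows. Statements on the series, on what has been measured and on what is new or still open speak of the compounds shown alone.

Measured compounds:
Compound 1, `CN(CC(=O)N1CCN(c2ccccc2)CC1)C(=O)c1ccc(S(C)(=O)=O)c([N+](=O)[O-])c1`; compound 2, `CS(=O)(=O)c1ccc(C(=O)N2CCC(C(=O)N3CCc4ccccc4C3)CC2)cc1[N+](=O)[O-]`.

In an ADME assay on HepG2 cells (Homo sapiens) for cytotoxicity, read by CellTiter-Glo and ATP content, with a stated time of 72 h (a lower number here means that less compound is needed, a higher number that more compound is needed for the effect), compound 1 gives > 27000 nM, which is a limit of the assay rather than a number. In this assay compound 2 gives > 27000 nM, again a limit of the assay and not a number. Among the measured compounds shown here, compound 2 therefore stands at the edge of what the assay can report, where both values so far sit (the limit of > 27000 nM in this assay, at which 2 of the 2 values shown sit), and no step between measured compounds can be drawn from these two.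

The account now turns to compound 3, `CN(Cc1ccccc1F)C(=O)C1CCN(C(=O)c2ccc(S(C)(=O)=O)c([N+](=O)[O-])c2)CC1`, which is still to be measured in this assay. It differs from compound 2 in a single place ((2-fluorobenzyl)(methyl)amino in place of 1,2,3,4-tetrahydroisoquinolin-2-yl on a carbonyl carbon). Since both measured values rest at the limit, no step beyond the usual scatter is expected in this assay, in either direction, and compound 3 is expected to return a limit again. The estimate for compound 3 in this assay is 30000 nM, with a range from 15000 nM to 60000 nM. The step that this estimate means, a step that the limit leaves unreadable from compound 2 to compound 3, is expected to lie within the scatter.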

Compound 3, half-maximal effective concentration: > 27000 nM
Compound 3: no number, only a limit; the forecaster's own chance of this, stated with the estimate: 85%; the middle value does not contradict the limit.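

In this assay compound 3 gives > 27000 nM, which is a limit of the assay and not a number. Compound 2 also stands at a limit, so no step from compound 2 to compound 3 can be read: the limit of > 27000 nM in this assay, at which 3 of the 3 values shown sit.

The compounds shown leave open how compound 1, compound 2 and compound 3 would compare in this assay if any of them returned a number.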